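A few compounds are considered here, and "the series" means these few. Any claim that something is new, unique, unknown or untested is made for them only; others in the source may bear on it.

Measured compounds:
- compound 1, `O=C(OCc1cccc(Cl)c1)c1cccc(=O)[nH]1`, in an assay on isolated protein for inhibition of matrix metalloproteinase-9 (Homo sapiens) (on this read-out higher numbers stand for weaker inhibition and lower numbers for stronger inhibition), compound 1 gives 67000 nM
- compound 2, `O=C(Oc1cccs1)c1cccc(=O)[nH]1`, in this assay compound 2 gives 70000 nM

Both numbers lie within the scatter of each other, so compound 1 and compound 2 show no difference worth reading. Among the measured compounds shown here, no pair of measured compounds here differs in a single place, so no measured step guides the next change. Compound 3, `O=C(OCc1cccc(C(F)(F)F)c1)c1cccc(=O)[nH]1`, differs from compound 1 by trifluoromethyl in place of chloro on an aromatic carbon. For the measured compounds named here, with no measured step of this kind to draw on, the step from compound 1 to compound 3 is expected to be a 1.0-fold higher number from compound 1 to compound 3 (0.02 log units; within the scatter), in this assay hardly beyond the scatter. Compound 3 is therefore expected to give about 70000 nM, estimated between 25000 nM and 200000 nM.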

Compound 3, half-maximal inhibitory concentration: > 150 nM
Compound 3 was reported as a limit; the forecaster's own chance of this, stated with the estimate: 20%; the middle value does not contradict the limit.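

In this assay compound 3 gives > 150 nM, which is a limit and not a number. The change from compound 1 to compound 3 yields no readable step. The compounds shown leave open how trifluoromethyl in place of chloro on an aromatic carbon bears on inhibition.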